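The source may report more compounds than this note shows. Statements on the series, on what has been measured and on what is new or still open speak of the compounds shown alone.

For the measured compounds named here, compound 1 `O=[N+]([O-])c1ccc(NC(=S)Nc2cccc(C(F)(F)F)c2)cc1` gives 10000 nM in an ADME assay on MDBK cells (Bos taurus) for cytotoxicity, read by MTT assay, with a stated time of 96 h (on this read-out lower numbers stand for higher toxicity in this test and higher numbers for lower toxicity in this test), the lowest of the two numbers measured so far. Going by the values given here, compound 2 `COc1cccc(NC(=S)Nc2cccc(C(F)(F)F)c2)c1`, the only other compound measured and so the nearest, gives 52000 nM, a higher number by a margin beyond the usual scatter. Compound 3 `CCOC(=O)c1ccc(NC(=S)Nc2cccc(C(F)(F)F)c2)cc1` keeps the core of compound 1 but carries ethoxycarbonyl in place of nitro on an aromatic carbon, para to a large group: ethoxycarbonyl in place of nitro on an aromatic carbon.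

Among the compounds with values here, no measured pair differs in one place only, so the data give no direct guide to this exchange. Within the data shown here, the only hint is that compound 2, at 52000 nM, shows that the shared core can read higher than the number for compound 1. A modest rise in this assay is therefore expected, pointing toward lower toxicity in this test. The expected size is a 2.0-fold higher number from compound 1 to compound 3 (0.30 log units; within the scatter), which lies near the edge of the scatter. Compound 3 is estimated at 20000 nM, with an expected range from 7000 nM to 60000 nM.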

Compound 3, half-maximal cytotoxic concentration: 64000 nM
The estimate for compound 3 lay 3.2-fold (0.51 log units) below the measured number; measured number above the stated range.
By their numbers in this assay, from the lowest: compound 1; then compounds 2 and 3 (each within the scatter of the next).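

In this assay, putting ethoxycarbonyl in place of nitro on an aromatic carbon, para to a large group, gives a 6.4-fold higher number from compound 1 to compound 3 (0.81 log units; beyond the scatter), a step beyond the usual scatter. For the compounds shown here, this is the first measured pair that differs in one place only, and it shows that the read-out at this position depends on the group it carries: with the rest of the molecule unchanged, the number moves toward lower toxicity in this test. The data offer no measured basis for explaining this step, so the change can be stated but not accounted for.

A single exchange cannot separate the loss of nitro from the arrival of ethoxycarbonyl, as both happen in the same step, and it gives no sign of whether the size of the step is particular to this pair. The compounds shown leave open how an amine, a carboxylic acid or a methyl ester would read at this same position, and whether the step would persist if the trifluoromethyl group of the shared core were exchanged for a chlorine atom.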